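The source may hold more compounds than are shown below. What is called first, only, known or untested is meant among the compounds shown, and "the series" means these compounds.

The study concerns an anilide with a saturated chain and a polar end group, measured in a functional assay on HCT-116 cells (Homo sapiens) for inhibition, read by colorimetric assay, with a stated time of 3 days; a higher number here means a weaker inhibitor, a lower number a stronger inhibitor. Compound 1 `NC(=O)C(=O)NCCCCCC(=O)Nc1ccccc1` carries a (carbamoylcarbonyl)amino end; in this assay compound 1 gives > 100000 nM, which is a limit of the assay and not a number. Compound 3 `CC(=O)C(=O)NCCCCC(=O)Nc1ccccc1` is built the same way with a shorter chain and a different acyl end, and in this assay compound 3 gives > 100000 nM, again only a limit. Going by the values given here, compound 2 `O=C(CCCCCCNC(=O)C(O)(O)C(F)(F)F)Nc1ccc(Cl)cc1`, with a chlorinated anilide and a hydrated trifluoromethyl carbonyl at the chain end, is the one compound with a measured number: in this assay compound 2 gives 4230 nM. Compound 1 therefore stands at the limit of > 100000 nM in this assay, at which 2 of the 3 values shown sit, so its position is known only as a limit.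

Compound 4 `O=C(CCCCCCC(O)C(F)(F)F)Nc1ccccc1` has not yet been measured. It differs from compound 1 by 3,3,3-trifluoro-2-hydroxypropyl in place of (carbamoylcarbonyl)amino on a saturated chain carbon, five bonds along the chain from a carbonyl carbon. Among the compounds with values here, no step between measured compounds is available to set the size of this change; the only measured number, that of compound 2, belongs to a different end group and anilide, so the expectation rests on it loosely. Compound 4 is estimated to reach 40000 nM, with a range from 8000 nM to 200000 nM, and the expected step is an at least 2.5-fold lower number from compound 1 to compound 4 (0.39 log units; beyond the scatter), a move toward stronger inhibition that may still end at a limit.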

Compound 4, half-maximal inhibitory concentration: > 40000 nM
Compound 4 gave a limit, no number; the forecaster's own chance of this, stated with the estimate: 45%; the middle value lies on the limit itself.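

In this assay, compound 1 and compound 4 both end at limits, so no step can be read between them. Compound 1 gives > 100000 nM, which is a limit and not a number. Compound 4 gives > 40000 nM, likewise only a limit. The compounds shown leave open whether 3,3,3-trifluoro-2-hydroxypropyl in place of (carbamoylcarbonyl)amino changes inhibition at all, and in which direction.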